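This account rests on a few compounds, and the source may have more. Where it says the series, first, only, none or still open, it means among the compounds named here.

Compound 1, `COc1cccc(-c2ccc(C(=O)N(Cc3cccc(OCCCCCC(=O)O)c3)C(C)C)cc2)c1`, in an ADME assay on Raji cells (Homo sapiens) for cytotoxicity, read by CellTiter-Glo and resazurin assay, with a stated time of 72 h (a higher number here means that more compound is needed for the effect, a lower number that less compound is needed), gives > 20900 nM, which is a limit of the assay and not a number.
Compound 2, `CCOC(=O)CCCCCOc1cccc(CN(C(=O)c2ccc(-c3cccc(OCc4ccccc4)c3)cc2)C(C)C)c1`, in this assay gives > 26000 nM, again a limit.
Compound 3, `CCOC(=O)CCCCCOc1cccc(CN(C(=O)c2ccc(-c3cccc(OC)c3)cc2)C(C)C)c1`, in this assay gives > 21000 nM, likewise a limit.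

Compound 3 therefore stands only at a limit, and the two companions shown alongside it stand at limits as well, so none of the three can be placed above or below the others. Compound 4, `CCOC(=O)CCCCCOc1cccc(CN(C(=O)c2ccc(Br)cc2)C(C)C)c1`, differs from compound 3 in one place: bromo in place of 3-methoxyphenyl on an aromatic carbon. Two measured steps lead into compound 3. The step that the two limits leave unreadable from compound 1 to compound 3 runs between two limits the limit of > 20900 nM in this assay, at which 1 of the 3 values shown sits (the limit of > 21000 nM in this assay, at which 1 of the 3 values shown sits), so its size cannot be read. The step that the two limits leave unreadable from compound 2 to compound 3 likewise runs between two limits the limit of > 26000 nM in this assay, at which 1 of the 3 values shown sits, the limit of > 21000 nM in this assay, at which 1 of the 3 values shown sits, and gives no readable size. Neither step touches the group that the change to compound 4 removes, and nothing shown reaches a number at all. The expectation for compound 4 is therefore a step of a number no higher from compound 3 to compound 4 (the limit leaves the size open) that again ends at a limit. Compound 4 is estimated at 21000 nM, within 8000 nM to 60000 nM.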

Compound 4, half-maximal effective concentration: > 26000 nM
Compound 4: no number, only a limit; the forecaster's own chance of this, stated with the estimate: 85%; middle value at least 1.2-fold (0.09 log units) away from the limit.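

Compound 4 gives > 26000 nM, which is a limit of the assay and not a number. Compound 3 also stands only at a limit, so the step between compound 3 and compound 4 cannot be read. The compounds shown leave open whether bromo in place of 3-methoxyphenyl changes the concentration needed for an effect in this assay.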